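This account rests on a few compounds, and the source may have more. Where it says the series, first, only, none or still open, it means among the compounds named here.

Measured so far, each value a limit and not a number:
- Compound 1 `COc1cc(OC)c(OC)cc1/C=C/COC(=O)/C=C/c1ccc(OC)c(OC)c1`: > 300 mg/kg
- Compound 2 `COc1cc(OC)c(OC)cc1/C=C/COC(=O)/C=C/c1c(OC)ccc(OC)c1OC`: > 300 mg/kg
- Compound 3 `COc1cc(OC)c(OC)cc1/C=C/COC(=O)/C=C/c1cc(OC)c(OC)c(OC)c1OC`: > 200 mg/kg

In a functional assay on the whole organism (strain Kunming) with Mus musculus as the target, with a stated time of 0.5 h (a higher number here means that more compound is needed for the effect, a lower number that less compound is needed), compound 1 gives > 300 mg/kg, which is a limit. It therefore stands at the limit of > 300 mg/kg in this assay, at which 2 of the 3 values shown sit.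

Compound 4 `COc1cc(OC)c(OC)cc1/C=C/COC(=O)/C=C/c1ccccc1C(F)(F)F` carries 2-(trifluoromethyl)phenyl in place of 3,4-dimethoxyphenyl on a double-bonded chain carbon bound to a double-bonded chain carbon.

Among the measured compounds shown here, no measured step shows what a change at this place does in this assay, so any expectation here is uncertain. The expected change is an at least 1.5-fold lower number from compound 1 to compound 4 (0.17 log units; that floor lies within the scatter), towards less compound needed, though another limit is about as likely as a number. For compound 4 the estimated value is 200 mg/kg, with an expected range of 70 mg/kg to 350 mg/kg.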

Compound 4, dose for half-maximal effect: > 300 mg/kg
Compound 4: only a limit was reported (the forecaster's own chance of this, stated with the estimate: 55%); at least 1.5-fold (0.17 log units) between middle value and limit.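

Compound 1 and compound 4 are both reported only as limits in this assay, so no step can be read between them. The compounds shown leave open whether 2-(trifluoromethyl)phenyl in place of 3,4-dimethoxyphenyl changes the dose needed at all.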